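From 4-fluorobenzyl to 4-methoxybenzyl in compound 2

The source may report more compounds than this note shows. Statements on the series, on what has been measured and on what is new or still open speak of the compounds shown alone.

In a functional assay on PC-9 cells (Homo sapiens) for inhibition, read by MTT assay, with a stated time of 72 h (a higher number here means a weaker inhibitor, a lower number a stronger inhibitor), compound 1 `Cc1cc(Nc2cc(-c3ccccc3)[nH]n2)n2nc(SCc3cccc(Br)c3)nc2n1` gives 8900 nM and compound 2 `Cc1cc(Nc2ccn(Cc3ccc(F)cc3)n2)n2nc(SCc3ccc(Br)cc3)nc2n1` gives 19400 nM as the higher of these two numbers. Compound 3 `CCCSc1nc2nc(C)cc(Nc3cc(-c4ccccc4)[nH]n3)n2n1` gives > 50000 nM as a limit of the assay and not a number.

Compound 4 `COc1ccc(Cn2ccc(Nc3cc(C)nc4nc(SCc5ccc(Br)cc5)nn34)n2)cc1` carries methoxy in place of fluoro on an aromatic carbon of compound 2, para to a large group, with the count of the change being methoxy in place of fluoro on an aromatic carbon here. Among the compounds with values here, the only measured step, an at least 5.6-fold higher number from compound 1 to compound 3 (0.74 log units; beyond the scatter) for ethyl in place of 3-bromophenyl on a saturated chain carbon bound to a sulfur, lies elsewhere in the structure and does not test this change. Within the data shown here, with no measured fluoro-to-methoxy step, no step beyond the scatter is expected in this assay and no direction is favoured. The expected step is a 1.0-fold higher number from compound 2 to compound 4 (0.01 log units; within the scatter) on this basis. For compound 4 the estimated value is 20000 nM with an expected range of 8000 nM to 45000 nM around it.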

Compound 4, half-maximal inhibitory concentration: > 50000 nM
Compound 4 was reported as a limit (the forecaster's own chance of this, stated with the estimate: 20%); middle value at least 2.5-fold (0.39 log units) away from the limit.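

In this assay, within the data shown here, this is the first reading at this position, on an aromatic carbon para to a large group, and swapping 4-fluorobenzyl for 4-methoxybenzyl gives an at least 2.5-fold higher number from compound 2 to compound 4 (0.41 log units; beyond the scatter), so methoxy in place of fluoro weakens inhibition rather than being tolerated. Compound 4 gives > 50000 nM, which is a limit of the assay and not a number. The step is therefore a lower bound, and its true size stays unread: the limit of > 50000 nM in this assay, at which 2 of the 4 values shown sit.

Going by these compounds, it remains open whether an amine, a chloro group or a plain benzyl at this position would give a number that can be read in this assay. Also open, on these data alone, is whether the methoxy-for-fluoro step would hold with a 3-bromobenzyl group on the sulfur, as in compound 1.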